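Swapping the aryl group on a shared core

The source may hold more compounds than are shown below. What is called first, only, known or untested is meant among the compounds shown, and "the series" means these compounds.

Three compounds share one core and differ only in the aromatic group attached to it. Compound 1 `COc1cc(-c2ccnc3cc(-c4ccc(F)cc4)nn23)cc(OC)c1OC` has the highest number of the three in a functional assay on A549 cells (Homo sapiens) for inhibition, read by CCK-8 assay, with a stated time of 48 h (on this read-out lower numbers stand for stronger inhibition and higher numbers for weaker inhibition), giving 3800 nM. Compound 2 `COc1cc(-c2ccnc3cc(-c4ccc(C)cc4)nn23)cc(OC)c1OC` gives 3 nM, and compound 3 `COc1cc(-c2ccnc3cc(-c4ccc5cc[nH]c5c4)nn23)cc(OC)c1OC` gives 170 nM. The step of a 1300-fold lower number from compound 1 to compound 2 (3.10 log units; beyond the scatter) and the step of a 22-fold lower number from compound 1 to compound 3 (1.35 log units; beyond the scatter) both show that replacing the 4-fluorophenyl group lowers the number strongly, though by very different amounts.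

Compound 4 `COc1cc(-c2ccnc3cc(-c4cn(C)c5ccccc45)nn23)cc(OC)c1OC` is not yet measured. Compared with compound 1 it carries a change: 1-methyl-1H-indol-3-yl in place of 4-fluorophenyl on an aromatic carbon. Like compound 3, this brings in a fused two-ring group, so the step from compound 1 to compound 3 bears most directly on it, while the step to compound 2 shows how far such a replacement can go. A clear drop in number is therefore expected, estimated as a 19-fold lower number from compound 1 to compound 4 (1.28 log units; beyond the scatter). For compound 4 the expected value in this assay is 200 nM, with a range from 30 nM to 1500 nM.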

Compound 4, half-maximal inhibitory concentration: 1340 nM
Compound 4: middle estimate off by 6.7-fold (0.83 log units), on the low side, within the range that was stated.
By their numbers in this assay, from the lowest: compound 2; then compound 3; then compound 4; then compound 1.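

In this assay, a fused two-ring group at this position does not by itself bring a large gain, as a 2.8-fold lower number from compound 1 to compound 4 (0.45 log units; beyond the scatter) shows. The two indole groups are also not interchangeable: a 7.9-fold higher number from compound 3 to compound 4 (0.90 log units; beyond the scatter) separates 1-methyl-1H-indol-3-yl from 1H-indol-6-yl, while a 450-fold higher number from compound 2 to compound 4 (2.65 log units; beyond the scatter) leaves the single-ring 4-methylphenyl group far ahead of 1-methyl-1H-indol-3-yl. Nothing available here accounts for these differences.

On these data alone, compounds 3 and 4 differ both in the methyl on the indole nitrogen and in the indole carbon that carries the bond to the shared core, so the share of each change stays open; 1H-indol-3-yl would separate them. As far as these compounds go, whether 4-ethylphenyl or 4-methoxyphenyl would keep the low number of compound 2 also stays open.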